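The source may hold more compounds than are shown below. What is called first, only, known or untested is meant among the compounds shown, and "the series" means these compounds.

Three compounds here share one core and differ only in the aryl group attached to the five-membered ring. Compound 1 `O=C(O)C[C@H](O)C[C@H](O)CCn1c(C(F)(F)F)nc(-c2ccccc2)c1-c1ccc(F)cc1` carries a plain phenyl group, and in an assay on microsomes from liver for inhibition of 3-hydroxy-3-methylglutaryl-coenzyme A reductase (Rattus norvegicus) (on this read-out higher numbers stand for weaker inhibition and lower numbers for stronger inhibition), compound 1 gives 31 nM. Compound 2 `COc1cccc(-c2nc(C(F)(F)F)n(CC[C@@H](O)C[C@@H](O)CC(=O)O)c2-c2ccc(F)cc2)c1` carries a 3-methoxyphenyl group, and in this assay compound 2 gives 20 nM. Compound 3 `COc1ccc(-c2nc(C(F)(F)F)n(CC[C@@H](O)C[C@@H](O)CC(=O)O)c2-c2ccc(F)cc2)cc1` carries a 4-methoxyphenyl group, and in this assay compound 3 gives 68 nM, the highest of the three numbers and so the weakest inhibition among them. The measured steps are a 1.6-fold lower number from compound 1 to compound 2 (0.19 log units; within the scatter), a 2.2-fold higher number from compound 1 to compound 3 (0.34 log units; beyond the scatter) and a 3.4-fold higher number from compound 2 to compound 3 (0.53 log units; beyond the scatter). Compound 4 `Cc1cc(C)cc(-c2nc(C(F)(F)F)n(CC[C@@H](O)C[C@@H](O)CC(=O)O)c2-c2ccc(F)cc2)c1` has not yet been measured; it differs from compound 3 by 3,5-dimethylphenyl in place of 4-methoxyphenyl on an aromatic carbon. The steps of a 2.2-fold higher number from compound 1 to compound 3 (0.34 log units; beyond the scatter) and a 3.4-fold higher number from compound 2 to compound 3 (0.53 log units; beyond the scatter) bear on this change, both modest and both placing compound 3 at the weak end, so a modest step downward in this assay is expected when the 4-methoxyphenyl group is exchanged. The step from compound 3 to compound 4 is estimated as a 2.7-fold lower number from compound 3 to compound 4 (0.43 log units; beyond the scatter). Compound 4 is therefore expected to give about 25 nM, with a likely range from 10 nM to 70 nM.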

Compound 4, half-maximal inhibitory concentration: 24 nM
Beside the measured number, compound 4's estimate is 1.0-fold (0.02 log units) above it, within the range that was stated.
By their numbers in this assay, from the lowest: compounds 2, 4 and 1 (each within the scatter of the next); then compound 3.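

In this assay, putting 3,5-dimethylphenyl in place of 4-methoxyphenyl gives a 2.8-fold lower number from compound 3 to compound 4 (0.45 log units; beyond the scatter), whereas a 1.2-fold higher number from compound 2 to compound 4 (0.08 log units; within the scatter) and a 1.3-fold lower number from compound 1 to compound 4 (0.11 log units; within the scatter) both stay within the usual scatter. This place on the shared core therefore accepts an aryl group with two substituents and an aryl group made of carbon only, without compound 4 parting from compound 1 or compound 2, while compound 3 alone stands apart among the four. Nothing measured here explains why compound 3 differs from the others.

Going by these compounds, all four aryl groups carry only hydrogen, methoxy or methyl as substituents, so it stays open how an amine or a carboxylic acid on the aryl group would fare in this assay. A longer chain at this place, or a ring other than phenyl, also remains untested among the compounds shown.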